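The source may hold more compounds than are shown below. What is called first, only, known or untested is meant among the compounds shown, and "the series" means these compounds.

The measured compounds in this series are:

compound 1, `C=C1C(=O)[C@]23C[C@@]1(O)CC[C@H]2c1ccc(OS(=O)(=O)c2ccc(C)cc2)c(C)c1[C@@H]3Cn1cc(-c2ccccn2)nn1`: 1810 nM
compound 2, `C=C1C(=O)[C@]23C[C@@]1(O)CC[C@H]2c1ccc(OS(=O)(=O)c2ccc(C)cc2)c(C)c1[C@@H]3Cn1cc(-c2ccc(Cl)cc2)nn1`: 1260 nM
compound 3, `Cc1ccc(S(=O)(=O)Oc2ccc3c(c2C)[C@H](Cn2cc(-c4ccc(Cl)cc4)nn2)[C@@]24CC(=O)[C@@](C)(CC[C@@H]32)C4)cc1`: > 20000 nM

All three were tested in a functional assay on HL-60 cells (Homo sapiens) for cytotoxicity, read by MTT assay, with a stated time of 4 days; a lower number here means a stronger inhibitor, a higher number a weaker inhibitor. Compound 2 gives 1260 nM and compound 1 gives 1810 nM. The difference between them is pyridin-2-yl in place of 4-chlorophenyl on an aromatic carbon, and the step it made was a 1.4-fold higher number from compound 2 to compound 1 (0.16 log units; within the scatter), so the two compounds cannot be told apart in this assay. Compound 3 returned only a limit in this assay, > 20000 nM, and no number. How the core of compound 3 differs from the core of compound 2 is not broken down here.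

Compound 4, `Cc1ccc(S(=O)(=O)Oc2ccc3c(c2C)[C@H](Cn2cc(-c4ccccn4)nn2)[C@@]24CC(=O)[C@@](C)(CC[C@@H]32)C4)cc1`, has not yet been measured. It stands to compound 3 as compound 1 stands to compound 2: the change is pyridin-2-yl in place of 4-chlorophenyl on an aromatic carbon, and it is the same change, at the same place. For the measured compounds named here, because the only measured instance of this change stayed within the scatter, at a 1.4-fold higher number from compound 2 to compound 1 (0.16 log units; within the scatter), and because compound 3 sits at the limit of > 20000 nM in this assay, at which 1 of the 3 values shown sits, the estimate for compound 4 rests on the expectation that this change does not move the value by much. Compound 4 is therefore expected to give about 25000 nM, with a range from 10000 nM to 60000 nM. The expected step is estimated at a step that the limit leaves unreadable from compound 3 to compound 4, and most likely compound 4 will also return only a limit rather than a number.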

Compound 4, half-maximal inhibitory concentration: > 20000 nM
Compound 4: a limit, no number; the forecaster's own chance of this, stated with the estimate: 75%; the middle value lies beyond the limit too.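

In this assay compound 4 returned only a limit, > 20000 nM, and no number. Compound 3 also returned only a limit, so no step can be read between compound 3 and compound 4. The compounds shown leave open where the actual values of these two compounds lie, and whether pyridin-2-yl in place of 4-chlorophenyl changes anything on the core they share.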